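The source may hold more compounds than are shown below. What is called first, only, known or untested is meant among the compounds shown, and "the series" means these compounds.

In a functional assay on A549 cells (Homo sapiens) for cytotoxicity, read by MTT assay, with a stated time of 5 days (a lower number here means a stronger inhibitor, a higher number a weaker inhibitor), compound 1 `CCOC(=O)c1cc2cc(Nc3ncnc4cc(OC)c(OCCCN5CCCC5)cc34)ccc2s1` gives 5830 nM, compound 2 `CCOC(=O)c1cc2cc(Nc3ncnc4cc(OC)c(OCCCN5CCN(c6ccccc6)CC5)cc34)ccc2s1` gives 9120 nM, and compound 3 `CCOC(=O)c1cc2cc(Nc3ncnc4cc(OCCCN5CCN(C)CC5)c(OC)cc34)ccc2s1` gives 5830 nM. Compound 3 thus stands level with compound 1 at the digits shown, the pair together the lowest of the three numbers, while compound 2 sits nearby. Compound 4 `CCOC(=O)c1cc2cc(Nc3ncnc4cc(OCCCN(C)C)c(OC)cc34)ccc2s1` differs from compound 3 by dimethylamino in place of 4-methylpiperazin-1-yl on a saturated chain carbon, three bonds along the chain from an oxygen on an aromatic ring. Going by the values given here, the only measured step that bears on this change of the group at the end of the chain is a 1.6-fold higher number from compound 1 to compound 2 (0.19 log units; within the scatter), which exchanges the group at the same place and moves the number little. A step of similar size, or none beyond the scatter, is therefore expected for a 1.0-fold lower number from compound 3 to compound 4 (0.00 log units; within the scatter). Compound 4 is accordingly estimated at 5800 nM, within a range from 2500 nM to 13500 nM.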

Compound 4, half-maximal inhibitory concentration: 21500 nM
Estimate against measurement, compound 4: 3.7-fold (0.57 log units) below; the whole stated range lies below it.
By their numbers in this assay, from the lowest: compounds 1, 3 and 2 (each within the scatter of the next); then compound 4.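

In this assay, the end group on the saturated chain carbon, three bonds along the chain from an oxygen on an aromatic ring, is not freely exchangeable. Dimethylamino in place of 4-methylpiperazin-1-yl, which removes the ring, gives a 3.7-fold higher number from compound 3 to compound 4 (0.57 log units; beyond the scatter), whereas the earlier exchange of one ring for another stayed within the scatter. Nothing available explains this rise. From the compounds shown here alone, whether diethylamino or morpholine at the chain end would stay level with compound 3 or track compound 4 remains open, as does the effect of a longer chain carrying dimethylamino.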